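The compounds below may be only part of what the source reports. "The series", "measured", "known", "first", "only" and "open" are said of these compounds alone.

Compound 1 `CCCn1cc(COc2cc(O)c3c(c2)O[C@H](c2ccc(OC)c(O)c2)CC3=O)nn1` in a functional assay on RAW264.7 cells (Mus musculus) for inhibition, read by Griess assay, with stated times of 2 h and 24 h (on this read-out higher numbers stand for weaker inhibition and lower numbers for stronger inhibition), gives 9670 nM, the top of the three numbers measured, though not separated from compound 3 `COc1ccc([C@@H]2C/C(=N\O)c3c(O)cc(OCc4cn(C5CCCC5)nn4)cc3O2)cc1O`, which gives 6880 nM, within the scatter of compound 1. Compound 2 `CCCn1cc(COc2cc(O)c3c(c2)O[C@H](c2ccc(OC)c(O)c2)C/C3=N\O)nn1` gives 2340 nM, beyond the scatter from compound 1 and the lowest number of the three. Compound 4 `COc1ccc([C@@H]2CC(=O)c3c(O)cc(OCc4cn(Cc5ccc(C)cc5)nn4)cc3O2)cc1O` is not yet measured; it differs from compound 1 by 4-methylphenyl in place of ethyl on a saturated chain carbon bound to an aromatic nitrogen. Within the data shown here, the only measured step that touches the group on the aromatic nitrogen is a 2.9-fold higher number from compound 2 to compound 3 (0.47 log units; beyond the scatter), a modest rise, taken between two compounds that themselves differ from compound 1 elsewhere. Among the measured compounds shown here, no measured step replaces a chain with an aromatic ring at that position, so the bearing of that step is loose. Compound 4 is therefore expected to sit near compound 1, with a change of a 1.1-fold higher number from compound 1 to compound 4 (0.06 log units; within the scatter) at most a small rise and possibly none beyond the scatter. The estimate for compound 4 is 11000 nM, with a range of 4500 nM to 27000 nM.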

Compound 4, half-maximal inhibitory concentration: 16800 nM
Beside the measured number, compound 4's estimate is 1.5-fold (0.18 log units) below it; measured number inside the range.
By their numbers in this assay, from the lowest: compound 2; then compounds 3, 1 and 4 (each within the scatter of the next, the first and the last beyond it).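

With the carbonyl of the shared core kept, 4-methylphenyl in place of ethyl on a saturated chain carbon bound to an aromatic nitrogen gives a 1.7-fold higher number from compound 1 to compound 4 (0.24 log units; within the scatter) in this assay. Among these compounds, this position therefore carries a six-membered aromatic ring without a separation from the propyl compound on this read-out, a replacement that no earlier compound showed; the earlier step at this position, a 2.9-fold higher number from compound 2 to compound 3 (0.47 log units; beyond the scatter), lies beyond the scatter but was taken on compounds without that carbonyl. Nothing available explains how this position behaves.

Open, on these data alone, is whether 4-methylbenzyl in the setting of compound 2 would stay as close to propyl as it does here. Also open, as far as these compounds go, is how a longer chain such as hexyl, or an amine or a carboxylic acid in place of the methyl on the benzyl ring, would read.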